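The compounds below may be only part of what the source reports. "The series", "measured", "known", "first", "only" and "open" are said of these compounds alone.

Compounds measured so far:
Compound 1 `Nc1scc(-c2cccc(C(F)(F)F)c2)c1C(=O)c1ccccc1` — in a functional assay on CHO cells for agonist activity at adenosine receptor A1 (Homo sapiens), read by fluorescence and ERK phosphorylation, with stated times of 30 min and 1.5 h, tested at 10 uM (on this read-out higher numbers stand for a stronger effect at the one concentration tested and lower numbers for a weaker effect), compound 1 gives 59%
Compound 2 `Nc1scc(-c2cccc(Cl)c2)c1C(=O)c1ccccc1` — in this assay compound 2 gives 52%

Compound 2 sits at the lower end of these two numbers, with compound 1 the nearer of them, but the step of a number 7 percentage points lower from compound 1 to compound 2 (within the scatter) lies within the usual scatter, so the two compounds cannot be told apart on this read-out. Compound 3 `Nc1scc(-c2cccc(Br)c2)c1C(=O)c1ccccc1` has not yet been measured. It differs from compound 2 by bromo in place of chloro on an aromatic carbon. Within the data shown here, the only step measured so far, a number 7 percentage points lower from compound 1 to compound 2 (within the scatter), concerns a different exchange at the same position and was itself within the scatter; no step involving bromo has been measured. The change from compound 2 to compound 3 is therefore expected to give a step of about a number 3 percentage points higher from compound 2 to compound 3 (within the scatter), that is, none beyond the scatter. For compound 3 in this assay the estimated value is 55%, expected to lie between 40% and 70%.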

Compound 3, a percentage reported as activity, at one concentration (the size of the read-out at that concentration, not a potency): 76%
The estimate for compound 3 lay 21 percentage points below the measured number; measured number outside the range, above it.
By their numbers in this assay, from the lowest: compounds 2 and 1 (each within the scatter of the next); then compound 3.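

Among these compounds, the one earlier exchange at this aromatic carbon stayed within the scatter, so the group there could have seemed to matter little. In this assay, replacing one halogen with another now gives a clear change, a number 24 percentage points higher from compound 2 to compound 3 (beyond the scatter), and bromo also separates from trifluoromethyl, a number 17 percentage points higher from compound 1 to compound 3 (beyond the scatter). The read-out therefore does respond to the group at this place, even when a single heavy atom is exchanged for a single heavy atom, but nothing available explains why bromo stands out.

On these data alone, these compounds carry only chloro, bromo and trifluoromethyl at this place, so it remains open how iodo, a methoxy group or an amine would read there. As far as these compounds go, each number also comes from a single concentration, so whether compound 3 differs from compound 2 in potency stays open too.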